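The source may report more compounds than this note shows. Statements on the series, on what has been measured and on what is new or still open speak of the compounds shown alone.

Compound 2 `Nc1nn(CCOCCO)c2nnc(-c3ccccc3)c(-c3ccccc3)c12` gives no measurable inhibition in a functional assay on HT-29 cells (Homo sapiens) for cytotoxicity; a higher number here means a weaker inhibitor, a lower number a stronger inhibitor: its value of > 100000 nM is a limit of the assay, not a number. Compound 1 `Nc1[nH]nc2nnc(-c3ccccc3-c3ccccc3)c(-c3ccccc3-c3ccccc3)c12` likewise gives only a limit there, > 100000 nM. Both values sit at the limit of > 100000 nM in this assay, at which 2 of the 2 values shown sit. Compound 3 `CC(=O)n1nc(N)c2c(-c3ccccc3)c(-c3ccccc3)nnc21` has not yet been measured; it differs from compound 2 by acetyl in place of 2-(2-hydroxyethoxy)ethyl on an aromatic nitrogen. Among the compounds with values here, with no measured step between compounds to lean on, the step from compound 2 to compound 3 is expected to be none beyond the scatter, a number no higher from compound 2 to compound 3 (the limit leaves the size open). Compound 3 is therefore estimated at 100000 nM, within 30000 nM to 300000 nM, and most likely reported again as a limit.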

Compound 3, half-maximal inhibitory concentration: > 100000 nM
Compound 3: a limit, no number; the forecaster's own chance of this, stated with the estimate: 85%; the middle value sits exactly at the limit.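

Within the data shown here, compound 2 and compound 3 both give only a limit in this assay, so no step between them can be read. The compounds shown leave open whether any change to the shared core gives a measurable value: the limit of > 100000 nM in this assay, at which 3 of the 3 values shown sit.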